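Distal aryl exchange in the pyridine amide series

The source may hold more compounds than are shown below. What is called first, only, known or untested is meant among the compounds shown, and "the series" means these compounds.

Compound 3 `O=C(Nc1ccc(Oc2ccnc3[nH]ccc23)cc1)c1ccc(-c2ccc(F)cc2F)cn1` is one of three measured members of this set. In a functional assay on A549 cells (Homo sapiens) for cytotoxicity, read by MTT assay, with a stated time of 72 h (on this read-out lower numbers stand for stronger inhibition and higher numbers for weaker inhibition), compound 3 gives > 10000 nM, which is a limit of the assay rather than a number. Compound 1 `O=C(Nc1ccc(Oc2ccnc3[nH]ccc23)cc1)c1ccc(-c2ccc(Cl)cc2)cn1` gives > 10000 nM in this assay, again a limit. Compound 2 `COc1ccc(-c2ccc(C(=O)Nc3ccc(Oc4ccnc5[nH]ccc45)cc3)nc2)cc1` gives > 10000 nM in this assay, also a limit. The steps a step that the two limits leave unreadable from compound 1 to compound 2, a step that the two limits leave unreadable from compound 1 to compound 3 and a step that the two limits leave unreadable from compound 2 to compound 3 therefore cannot be sized, since (the limit of > 10000 nM in this assay, at which 3 of the 3 values shown sit).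

Compound 4 `CCc1ccc(-c2ccc(C(=O)Nc3ccc(Oc4ccnc5[nH]ccc45)cc3)nc2)cc1` differs from compound 3 in one place: 4-ethylphenyl in place of 2,4-difluorophenyl on an aromatic carbon. Going by the values given here, none of the measured steps bears readably on this exchange; every earlier variation of the distal aryl group left the value at the limit, so no direction or size can be read from them. Compound 4 is accordingly expected to sit at or close to the limit as well, with an estimated value of 15000 nM in a range from 5000 nM to 50000 nM. The expected step is a step that the limit leaves unreadable from compound 3 to compound 4, that is, nothing beyond the usual scatter, with the chance that the assay again reports only a limit judged high.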

Compound 4, half-maximal inhibitory concentration: > 10000 nM
Compound 4: a limit, no number; the forecaster's own chance of this, stated with the estimate: 80%; the middle value is on the limit's open side.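

In this assay compound 4 gives > 10000 nM, a limit and not a number. Its steps to compound 1, compound 2 and compound 3 therefore cannot be read: the limit of > 10000 nM in this assay, at which 4 of the 4 values shown sit.

The compounds shown leave open whether any distal aryl group on the shared core gives a number rather than a limit in this assay.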